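The source may hold more compounds than are shown below. What is called first, only, known or untested is meant among the compounds shown, and "the series" means these compounds.

The series shares one core, varied in the aryl group on the ring nitrogen. Compound 1 `Cc1ccc(-n2cnc3cnc(-c4ccc(F)cc4C)cc32)cc1` carries the simplest variant, and in an ADME assay on S9 fraction from liver (Mus musculus) for metabolic stability, read by LC-MS, using NADPH, with a stated time of 45 min, tested at 3 uM, in the presence of a further agent that is not named here (a lower number here means that the liver removes a smaller share, a higher number that the liver removes a larger share of the compound in one pass), compound 1 returned "not determined" (no result reported). For the measured compounds named here, compound 2 `COc1ccc(-n2cnc3cnc(-c4ccc(F)cc4C)cc32)cn1` gives 0.39 in this assay, while compound 3 `COc1ccc(-n2cnc3cnc(-c4ccc(F)cc4C)cc32)nc1` gives 0.66, which is the higher of the two numbers measured; the change a number 0.27 higher from compound 2 to compound 3 (beyond the scatter) is the only step so far, and it lies beyond the scatter.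

Compound 4 `COc1cnc(-n2cnc3cnc(-c4ccc(F)cc4C)cc32)cn1` is the next member, not yet measured. It differs from compound 3 in one place: 5-methoxypyrazin-2-yl in place of 5-methoxypyridin-2-yl on an aromatic nitrogen. Going by the values given here, no measured step involves a pyrazine, so the one step in hand, a modest rise, bears only loosely on this change, and the direction of any shift cannot be read from it. Compound 4 is therefore expected to sit near compound 3, with a step of a number 0.060 lower from compound 3 to compound 4 (within the scatter) that is estimated to stay within the scatter. The estimate for compound 4 in this assay is 0.6, with a range from 0.4 to 0.8.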

Compound 4, hepatic extraction ratio: 0.66
Beside the measured number, compound 4's estimate is 0.060 below it; the measured number falls inside the stated range.
By their numbers in this assay, from the lowest: compound 2; then compounds 3 and 4 (each within the scatter of the next).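

In this assay, the 5-methoxypyrazin-2-yl group gives no change at the digits printed from compound 3 to compound 4 (within the scatter) against the 5-methoxypyridin-2-yl group, so at this place on the aromatic nitrogen a second hetero atom in the six-membered ring leaves the hepatic extraction ratio within the scatter. The 6-methoxypyridin-3-yl group remains separate, with a number 0.27 higher from compound 2 to compound 4 (beyond the scatter) when the 5-methoxypyrazin-2-yl group replaces it, a step of the same size as the earlier one to the 5-methoxypyridin-2-yl group. Nothing measured alongside these numbers explains the result.

The compounds shown leave open how the hepatic extraction ratio responds when an amine or a carboxylic acid stands in place of the methoxy group on these rings. Compound 1 gives "not determined" (no result reported), so the simplest variant offers no comparison with the three methoxy compounds.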